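The source may report more compounds than this note shows. Statements on the series, on what has been measured and on what is new or still open speak of the compounds shown alone.

Compound 1 `O=C(O)COc1ccc(NC(=O)COc2ccccc2)cc1F` gives 29.8% in a functional assay on CHO cells for agonist activity at Free fatty acid receptor 1 (Homo sapiens), read by FLIPR, tested at 100 nM; on this read-out lower numbers stand for a weaker effect and higher numbers for a stronger effect at the one concentration tested. Compound 2 `CC(Oc1ccccc1F)C(=O)Nc1ccc(OCC(=O)O)c(F)c1` gives 35.1% in this assay. Compound 3 `CC(C)(C)c1ccc(OCC(=O)Nc2ccc(OCC(=O)O)c(F)c2)cc1` gives 7.65% in this assay.

Compound 2 shows the highest of the three numbers, but compound 1 lies within the scatter of it; only compound 3 stands clearly lower. Compound 4 `Cc1ccc(C)c(OC(C)C(=O)Nc2ccc(OCC(=O)O)c(F)c2)c1` arises from compound 2 by 2,5-dimethylphenyl in place of 2-fluorophenyl on an oxygen on a saturated carbon. Among the compounds with values here, the one measured step that bears on this is a number 22.2 percentage points lower from compound 1 to compound 3 (beyond the scatter), where an alkyl group entered the same kind of ring. Here two methyls enter and a fluorine leaves, so a step in the same direction but of lesser size is expected in this assay. Compound 4 is therefore estimated at 22%, between 8% and 38%. The expected step is a number 13.1 percentage points lower from compound 2 to compound 4 (beyond the scatter).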

Compound 4, a percentage reported as activity, at one concentration (the size of the read-out at that concentration, not a potency): 18.7%
Compound 4: the middle estimate sits 3.3 percentage points above what was measured; low and high end bracket the measured number.
By their numbers in this assay, from the lowest: compound 3; then compound 4; then compounds 1 and 2 (each within the scatter of the next).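

In this assay, 2,5-dimethylphenyl in place of 2-fluorophenyl on the oxygen gives a number 16.4 percentage points lower from compound 2 to compound 4 (beyond the scatter), so the number also responds to the ring substituents in the series carrying the chain methyl. Together with a number 22.2 percentage points lower from compound 1 to compound 3 (beyond the scatter), this gives a second case of alkyl groups on this ring accompanying a lower number. The fluorine left and the two methyls entered in the same step. The step cannot be divided between them. Going by these compounds, it remains open whether a single methyl, a chlorine or a methoxy group on this ring would behave alike, and nothing measured here accounts for the step.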